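Toward the clearance of compound 3

A few compounds are considered here, and "the series" means these few. Any claim that something is new, unique, unknown or untested is made for them only; others in the source may bear on it.

compound 1 `COCC1=C[C@@](C)(c2cc(NC(=O)c3ccc(C#N)cn3)ccc2F)N=C(N)O1` gives 12.9 mL/min/kg
compound 2 `C[C@@]1(c2cc(NC(=O)c3cnc(OCF)cn3)ccc2F)C=C(CF)OC(N)=N1` gives 34.4 mL/min/kg

In an ADME assay on the whole organism (strain Sprague-Dawley) for pharmacokinetics, with Rattus norvegicus as the target, read by LC-MS, using cassette dosing, at a dose of 0.5 mg/kg by the intravenous route (on this read-out higher numbers stand for fast clearance and lower numbers for slow clearance), compound 2 has the higher of the two numbers at 34.4 mL/min/kg, and compound 1 lies lower at 12.9 mL/min/kg, a gap beyond the scatter. The two differ in more than one place, so their gap isolates no single change.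

Compound 3 `C[C@@]1(c2cc(NC(=O)c3ncc(C#N)cc3Cl)ccc2F)C=C(CF)OC(N)=N1` carries 3-chloro-5-cyanopyridin-2-yl in place of 5-(fluoromethoxy)pyrazin-2-yl on a carbonyl carbon. Among the measured compounds shown here, no measured pair shows this change alone. For the measured compounds named here, the only guide is that compound 1, which also bears a nitrile, stands at 12.9 mL/min/kg. A modest downward step is therefore expected, one likely to stay within the scatter. The expected step is a 1.7-fold lower number from compound 2 to compound 3 (0.24 log units; within the scatter). For compound 3 the estimated clearance is 20 mL/min/kg, with an expected range of 9 mL/min/kg to 42 mL/min/kg.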

Compound 3, clearance: 30.6 mL/min/kg
Compound 3: middle estimate off by 1.5-fold (0.18 log units), on the low side, and the stated range covers the measured number.
By their numbers in this assay, from the lowest: compound 1; then compounds 3 and 2 (each within the scatter of the next).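

Among the compounds shown here, this is the first pair that differ in one place: on a carbonyl carbon whose other neighbour is an amide-type nitrogen, 3-chloro-5-cyanopyridin-2-yl in place of 5-(fluoromethoxy)pyrazin-2-yl gives a 1.1-fold lower number from compound 2 to compound 3 (0.05 log units; within the scatter) in this assay. The exchange replaces the whole ring, with one hetero atom fewer and a nitrile and a chlorine entering together, yet on this read-out the two compounds cannot be told apart, so at this position the two groups are interchangeable as far as clearance shows. Nothing shown here explains that result.

As far as these compounds go, what the nitrile and the chlorine each contribute remains open. So does what a trifluoromethyl group or an amine on that ring would do to the clearance.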